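The compounds below may be only part of what the source reports. "The series", "measured", "known", "first", "only" and "open" are said of these compounds alone.

Measured in a functional assay on RAW264.7 cells (Mus musculus) for inhibition, read by fluorescence and resazurin assay, with a stated time of 48 h; on this read-out higher numbers stand for weaker inhibition and lower numbers for stronger inhibition:

compound 1 `CCCCCCCCC/C=C\CCCC1CC(=O)c2ccccc2N1C` — 24 ug/mL
compound 2 `CCCCCCCC/C=C\CCCCC1CC(=O)c2ccccc2N1C` — 24 ug/mL
compound 3 `CCCCCCCC/C=C/C1CC(=O)c2ccccc2N1C` — 24 ug/mL

All three measured compounds share the same core and a methyl on the ring nitrogen, differing only in the length and placement of the unsaturated chain. On the half-maximal inhibitory concentration in this assay compound 3 stands level with compound 1 and compound 2 at the digits shown; the three values lie within the scatter of one another, so no order among them can be read from these numbers.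

Compound 4 `CCCCCCCCCCC/C=C/C1CC(=O)c2ccccc2N1C` is the next member to be measured. Relative to compound 3 it carries propyl in place of hydrogen on a saturated chain carbon, eight bonds along the chain from a double-bonded chain carbon, a lengthening of the saturated part of the chain by three carbons. No pair of measured compounds differing in a single place is available, so no measured step can anchor the expectation; what the three measured compounds show is that a change of chain length or double-bond position left the read-out unchanged at the digits shown.

Compound 4 is therefore expected to give 24 ug/mL in this assay, with a range of 12 ug/mL to 48 ug/mL. The expected step of no change at the digits printed from compound 3 to compound 4 (within the scatter) is none beyond the scatter.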

Compound 4, half-maximal inhibitory concentration: 24 ug/mL
Compound 4: middle estimate and measured number agree at the digits printed; the range from low to high includes it.
By their numbers in this assay, from the lowest: compounds 1, 2, 3 and 4 (each within the scatter of the next).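

In this assay, among these compounds, propyl in place of hydrogen on a saturated chain carbon, eight bonds along the chain from a double-bonded chain carbon, is the first change in a single place that can be read, and it gives no change at the digits printed from compound 3 to compound 4 (within the scatter). Among the compounds shown here, the earlier compounds offered no such pair, so this is the first direct sign that the read-out does not respond to an addition at this position, though it rests on one step only. Nothing measured alongside this step speaks to why the read-out holds.

On these data alone, whether an amine or a carboxylic acid in place of the propyl, or a longer chain, would move the read-out stays open. Also open, as far as these compounds go, is whether the same addition would leave the chains of compound 1 and compound 2 equally unmoved.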